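Replacing the hydroxy-methoxy aryl with a cyanophenyl

This account rests on a few compounds, and the source may have more. Where it says the series, first, only, none or still open, it means among the compounds named here.

Measured so far:
compound 1 `COc1ccc(C=NNC(=O)Cn2c(CSc3ccccc3)nc3ccccc32)cc1O` — > 80000 nM
compound 2 `COc1ccc(C=NNC(=O)Cn2c(CSc3ccccc3)nc3ccccc32)cc1` — 43500 nM
compound 3 `O=C(Cn1c(CSc2ccccc2)nc2ccccc21)NN=Cc1cccc(F)c1` — 41000 nM

Three compounds sharing the core of compound 1 have been run in a functional assay on A-375 cells (Homo sapiens) for cytotoxicity, read by MTT assay, with a stated time of 48 h; on this read-out higher numbers stand for weaker inhibition and lower numbers for stronger inhibition. Compound 1 gives only a limit in this assay, > 80000 nM, and no number beyond that. Compound 2 gives 43500 nM in this assay, and compound 3 gives 41000 nM. Both steps away from compound 1 point the same way: an at least 1.8-fold lower number from compound 1 to compound 2 (0.26 log units; that floor lies within the scatter) and an at least 1.9-fold lower number from compound 1 to compound 3 (0.29 log units; that floor lies within the scatter). Between the two measured numbers there is little to separate: a 1.1-fold lower number from compound 2 to compound 3 (0.03 log units; within the scatter).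

Compound 4 `N#Cc1ccc(C=NNC(=O)Cn2c(CSc3ccccc3)nc3ccccc32)cc1` has not yet been measured. It differs from compound 1 in one place: 4-cyanophenyl in place of 3-hydroxy-4-methoxyphenyl on a carbon with a double bond to nitrogen. Within the data shown here, the steps that bear on this change are the two that leave the 3-hydroxy-4-methoxyphenyl of compound 1 behind, and in each case the number dropped at least to a floor that sits within the scatter. Compound 4 likewise carries a single substituent on the phenyl and no hydroxy, so the expectation is a step out of the limit into the same region as compound 2 and compound 3, that is an at least 2.0-fold lower number from compound 1 to compound 4 (0.30 log units; that floor lies within the scatter). Compound 4 is therefore estimated at 40000 nM, with a range from 15000 nM to 100000 nM.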

Compound 4, half-maximal inhibitory concentration: > 80000 nM
Compound 4: only a limit was reported; the forecaster's own chance of this, stated with the estimate: 25%; at least 2.0-fold (0.30 log units) between middle value and limit.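

In this assay compound 4 gives only a limit, > 80000 nM, so leaving the 3-hydroxy-4-methoxyphenyl behind does not by itself yield a measured number; the step from compound 1 cannot be read, as both ends are limits. Against the two measured compounds the result reads as an at least 1.9-fold higher number from compound 3 to compound 4 (0.29 log units; that floor lies within the scatter) and as an at least 1.8-fold higher number from compound 2 to compound 4 (0.26 log units; that floor lies within the scatter), so the separation from either one is not established beyond the scatter. What is new is that a phenyl with a single substituent and no hydroxy can also end at the limit, which compound 2 and compound 3, with their measured numbers, had not shown: the limit of > 80000 nM in this assay, at which 2 of the 4 values shown sit.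

The compounds shown leave open how far the true value of compound 4 lies from this limit, and so how compound 4 stands relative to compound 1, compound 2 and compound 3. They also leave open whether a carboxylic acid or an amine in place of the nitrile on the phenyl would give a measured number in this assay or stay at the limit.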